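From methyl to fluoro: what compound 4 may do

The source may hold more compounds than are shown below. What is called first, only, known or untested is meant among the compounds shown, and "the series" means these compounds.

In a functional assay on CCRF-CEM cells (Homo sapiens) for antiproliferative activity, read by trypan blue exclusion, with a stated time of 72 h (a higher number here means a weaker inhibitor, a lower number a stronger inhibitor), compound 1 (`C[C@@H](Br)C(=O)Nc1cccc(C(=O)NC(N)=O)c1`) gives 1470 nM and compound 2 (`C[C@H](Br)C(=O)Nc1cccc(C(=O)NC(N)=O)c1`) gives 1470 nM. Compound 3 (`Cc1ccc(C(=O)NC(N)=O)cc1NC(=O)C(C)Br`) has the highest number of the three, at 3360 nM, which makes it the weakest inhibitor so far. Compound 4 (`CC(Br)C(=O)Nc1cc(C(=O)NC(N)=O)ccc1F`) differs from it as follows: fluoro in place of methyl on an aromatic carbon. Among the measured compounds shown here, the only measured step, no change at the digits printed from compound 1 to compound 2 (within the scatter), reflects (the fact that compounds 1 and 2 differ only in the configuration as drawn), so it does not touch this aromatic carbon. Compound 1, which carries neither methyl nor fluoro there, gives 1470 nM, and this offers only a loose guide. In this assay, no step beyond the scatter is expected. The estimated step is a 1.5-fold lower number from compound 3 to compound 4 (0.18 log units; within the scatter). For compound 4 the estimated value is 2200 nM, with an expected range from 1000 nM to 4800 nM.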

Compound 4, half-maximal inhibitory concentration: 3130 nM
For compound 4 the middle estimate is 1.4-fold (0.15 log units) below the measured one; low and high end bracket the measured number.
By their numbers in this assay, from the lowest: compounds 1 and 2 (each within the scatter of the next); then compounds 4 and 3 (each within the scatter of the next).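

In this assay the swap gives a 1.1-fold lower number from compound 3 to compound 4 (0.03 log units; within the scatter) and so methyl and fluoro read alike on this aromatic carbon, ortho to the ((1-bromoethyl)carbonyl)amino group. Among the compounds shown here, the earlier compounds offered only methyl as a group here, so this is the first direct comparison of two groups at this place. Nothing known about these compounds explains this match.

From the compounds shown here alone, whether an amine, a carboxylic acid or a longer chain on this same carbon would move the number beyond the scatter remains open.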